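The compounds below may be only part of what the source reports. "The series", "measured", "known", "first", "only" and "open" are said of these compounds alone.

compound 1 `Cc1nn(C)c2nc(NNC(=O)Nc3cc(Cl)nc(Cl)c3)cc(C3CC3)c12`: 80800 nM
compound 2 `CCCc1cc(NNC(=O)Nc2cc(Cl)nc(Cl)c2)nc2c1c(C)nn2C`: 40800 nM
compound 3 `Cc1nn(C)c2nc(NNC(=O)Nc3cc(Cl)nc(Cl)c3)cc(-c3ccco3)c12`: > 100000 nM

All three values come from a functional assay on SW620/5-FU cells (Homo sapiens) for cytotoxicity, read by MTT assay, with a stated time of 48 h, in the presence of a further agent that is not named here; a higher number here means that more compound is needed for the effect, a lower number that less compound is needed. Compound 3 stands at the limit of > 100000 nM in this assay, at which 1 of the 3 values shown sits, which is a limit of the assay and not a number.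

Compound 4 `Cc1nn(C)c2nc(NNC(=O)Nc3cc(Cl)nc(Cl)c3)cc(-c3ccccc3)c12` is the next step, with phenyl in place of furan-2-yl on an aromatic carbon. The measured steps all concern this same carbon. Changing cyclopropyl to propyl gave a 2.0-fold lower number from compound 1 to compound 2 (0.30 log units; within the scatter). Furan-2-yl in place of cyclopropyl gave an at least 1.2-fold higher number from compound 1 to compound 3 (0.09 log units; that floor lies within the scatter). Furan-2-yl in place of propyl gave an at least 2.4-fold higher number from compound 2 to compound 3 (0.38 log units; beyond the scatter). Among the measured compounds shown here, no measured step has phenyl entering, so the size of this change has to be inferred.

The expectation rests on compound 1 at 80800 nM and compound 2 at 40800 nM, both high numbers in this assay. Only a small step towards a lower number is expected, and a reading at the assay limit remains quite possible. The expected step is an at least 1.4-fold lower number from compound 3 to compound 4 (0.15 log units; that floor lies within the scatter). Compound 4 is estimated at 70000 nM, with an expected range of 25000 nM to 100000 nM.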

Compound 4, half-maximal effective concentration: 22900 nM
For compound 4 the middle estimate is 3.1-fold (0.49 log units) above the measured one; measured number outside the range, below it.
By their numbers in this assay, from the lowest: compounds 4, 2 and 1 (each within the scatter of the next, the first and the last beyond it). At a limit, above all of these: compound 3.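

In this assay, the carbon opposite the ring nitrogen distinguishes between two aromatic rings: phenyl in place of furan-2-yl gives an at least 4.3-fold lower number from compound 3 to compound 4 (0.64 log units; beyond the scatter), so an aromatic ring at this carbon does not by itself keep the reading at the top of the range. Phenyl in place of cyclopropyl gives a 3.5-fold lower number from compound 1 to compound 4 (0.55 log units; beyond the scatter), the first step away from the cyclopropyl compound that lies beyond the scatter, while phenyl in place of propyl gives a 1.8-fold lower number from compound 2 to compound 4 (0.25 log units; within the scatter), which leaves those two compounds unordered. Compound 3 stands at a limit of the assay and not at a number, so its step to the phenyl compound has only a floor: the limit of > 100000 nM in this assay, at which 1 of the 4 values shown sits.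

From the compounds shown here alone, the full size of the difference between phenyl and furan-2-yl stays open, and compound 4 at 22900 nM still needs a high concentration. Going by these compounds, whether a methoxy group on the phenyl, an amine or a longer chain at this carbon would take the number further down also stays open.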